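One Added Methyl on Compound 2

The source may hold more compounds than are shown below. What is called first, only, known or untested is meant among the compounds shown, and "the series" means these compounds.

Compound 1 `CC(C)N1C(=O)COc2ccc(-c3cnc(Cl)c(NS(=O)(=O)c4ccc(F)cc4)c3)cc21`: 5380 nM
Compound 2 `O=C1COc2ccc(-c3cccc(NS(=O)(=O)c4ccc(F)cc4)c3)cc2N1c1ccccc1`: 17700 nM

Both compounds were tested in a functional assay on HeLa cells (Homo sapiens) for antiproliferative activity, read by MTT assay, with a stated time of 72 h; a lower number here means a stronger inhibitor, a higher number a weaker inhibitor. Compound 2, at 17700 nM, has the higher of the two numbers, which makes it the weaker inhibitor, and the gap to compound 1 lies beyond the usual scatter of repeated measurements. These two compounds differ in more than one place, so their gap says little about any single change.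

The next compound, compound 3 `Cc1ccc(N2C(=O)COc3ccc(-c4cccc(NS(=O)(=O)c5ccc(F)cc5)c4)cc32)cc1`, keeps the structure of compound 2 except for one spot, where a phenyl becomes a 4-methylphenyl: methyl in place of hydrogen on an aromatic carbon. For the measured compounds named here, no measured pair here shows what such a change does in this assay. The change is small, so the expectation is no step beyond the scatter, and neither direction can be ruled out. The estimated result is a 1.2-fold lower number from compound 2 to compound 3 (0.07 log units; within the scatter). For compound 3 the expected value is 15000 nM, with an estimated range of 6000 nM to 35000 nM.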

Compound 3, half-maximal inhibitory concentration: > 40000 nM
Compound 3 ended at the assay's limit; the forecaster's own chance of this, stated with the estimate: 10%; middle value at least 2.6-fold (0.42 log units) from the limit.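

Going from phenyl to 4-methylphenyl gives an at least 2.2-fold higher number from compound 2 to compound 3 (0.35 log units; beyond the scatter) in this assay. This is the only pair shown that differs in one place, and it shows that even a single methyl, para to a large group, can weaken the compound by more than the usual scatter, so this position is sensitive to a very small addition. Compound 3 gives > 40000 nM, which is a limit of the assay and not a number, so only the minimum size of the step can be read, and its full size stays unknown: the limit of > 40000 nM in this assay, at which 1 of the 3 values shown sits.

These compounds leave the loss unexplained. One pair cannot show whether the result belongs to the methyl itself or to any addition at this position. A methoxy group, an amine or a carboxylic acid in the same place, or a methyl placed elsewhere on the phenyl, would be needed to tell whether this spot turns away every added group or only some of them.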